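The source may hold more compounds than are shown below. What is called first, only, known or untested is meant among the compounds shown, and "the series" means these compounds.

Compound 1 `Cc1nc(C(NC(=O)C(=O)Nc2ccc(Cl)cc2)C2CCCCN2)sc1CO`, in an ADME assay on TZM-b1 cells (Homo sapiens) for cytotoxicity, read by XTT assay, with a stated time of 3 days; on this read-out lower numbers stand for higher toxicity in this test and higher numbers for lower toxicity in this test: > 22000 nM, a limit of the assay.
Compound 2 `Cc1nc(C(NC(=O)C(=O)Nc2ccc(Cl)c(F)c2)C2CCCCN2)sc1CO`, in this assay : 58400 nM.
Compound 3 `Cc1nc(C(NC(=O)C(=O)Nc2ccc(F)cc2)C2CCCCN2)sc1CO`, in this assay : > 90000 nM, a limit of the assay.

Compound 3 therefore stands only at a limit in this assay, with no exact number. Compound 4 `Cc1nc(C(NC(=O)C(=O)NC2CCCCCC2)C2CCCCN2)sc1CO` differs from compound 3 by cycloheptyl in place of 4-fluorophenyl on an amide-type nitrogen. Of the measured steps, the change on the same amide-type nitrogen from compound 2 to compound 3 is the one that bears on it, and it reads an at least 1.5-fold higher number from compound 2 to compound 3 (0.18 log units; that floor lies within the scatter). The other two steps, a step that the limit leaves unreadable from compound 1 to compound 2 and a step that the two limits leave unreadable from compound 1 to compound 3, are not readable because of the limits the limit of > 22000 nM in this assay, at which 1 of the 3 values shown sits, and (the limit of > 90000 nM in this assay, at which 1 of the 3 values shown sits). No step beyond the scatter is expected, so the step from compound 3 to compound 4 is estimated as an at least 1.0-fold lower number from compound 3 to compound 4 (0.02 log units; that floor lies within the scatter). Compound 4 is expected to give about 85000 nM, within 30000 nM to 250000 nM.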

Compound 4, half-maximal cytotoxic concentration: > 90000 nM
Compound 4: only a limit was reported; the forecaster's own chance of this, stated with the estimate: 60%; at least 1.0-fold (0.02 log units) between middle value and limit.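

Among these compounds, on this amide-type nitrogen, the earlier compounds all carried a halogen-bearing phenyl ring, and compound 4 brings in cycloheptyl, a non-aromatic ring of carbon only. In this assay, compound 4 gives > 90000 nM, which is a limit of the assay and not an exact number. Among the compounds shown here, the one readable step is an at least 1.5-fold higher number from compound 2 to compound 4 (0.18 log units; that floor lies within the scatter), while the steps to compound 4 from compound 1 and compound 3 cannot be read.

From the compounds shown here alone, whether cycloheptyl and 4-fluorophenyl truly differ here stays open. So does what a cyclohexyl ring carrying an amine or a carboxylic acid would give on this nitrogen.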